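Permeability notes: aryloxy variation on the shared core

The compounds below may be only part of what the source reports. "The series", "measured", "known", "first", "only" and "open" are said of these compounds alone.

Measured compounds:
compound 1 `Cc1ccc(Oc2ccc3nc(COc4cccc(C(=O)O)c4)n(C)c3n2)c(C)c1`, 28.8 10^-6 cm/s
compound 2 `Cn1c(COc2cccc(C(=O)O)c2)nc2ccc(Oc3ccc4c(c3)CCC4)nc21`, 31.5 10^-6 cm/s
compound 3 `Cn1c(COc2cccc(C(=O)O)c2)nc2ccc(Oc3cccc(Cl)n3)cc21`, 7.6 10^-6 cm/s

In an ADME assay for permeability, using PAMPA, with a stated time of 4 h (a higher number here means that the compound crosses the layer faster, a lower number that the compound crosses the layer more slowly), compound 3 stands lowest of the three; compound 1 is nearest and compound 2 furthest, both beyond the scatter. Among the measured compounds shown here, the only measured step, a 1.1-fold higher number from compound 1 to compound 2 (0.04 log units; within the scatter), concerns a different aryl group and lies within the scatter.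

Compound 4 `Cc1cnc(Oc2ccc3nc(COc4cccc(C(=O)O)c4)n(C)c3c2)c(F)c1` follows from compound 3 by 3-fluoro-5-methylpyridin-2-yl in place of 6-chloropyridin-2-yl on an oxygen on an aromatic ring. For the measured compounds named here, no measured step bears on this exchange, so the expectation is anchored on compound 3 alone: no step beyond the scatter is expected, a 1.3-fold higher number from compound 3 to compound 4 (0.12 log units; within the scatter). For compound 4 in this assay a value of 10 10^-6 cm/s is estimated, with a range of 5 10^-6 cm/s to 20 10^-6 cm/s.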

Compound 4, apparent permeability: 5.8 10^-6 cm/s
Compound 4: middle estimate off by 1.7-fold (0.24 log units), on the high side, within the range that was stated.
By their numbers in this assay, from the lowest: compounds 4 and 3 (each within the scatter of the next); then compounds 1 and 2 (each within the scatter of the next).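

On an oxygen on an aromatic ring, 3-fluoro-5-methylpyridin-2-yl in place of 6-chloropyridin-2-yl gives a 1.3-fold lower number from compound 3 to compound 4 (0.12 log units; within the scatter) in this assay. Among the compounds shown here, this is the first reading at this position on this core: the chlorine can give way to a fluorine plus a methyl with no step beyond the scatter. The data hold nothing that explains this result. Going by these compounds, the separate share of the fluorine and the methyl remains open, since both change in one step. Also open, on these data alone, is how a pyridin-2-yl group carrying an amine or a longer alkyl chain would read.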